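A chain-end swap on a weak antagonist series

This account rests on a few compounds, and the source may have more. Where it says the series, first, only, none or still open, it means among the compounds named here.

Two measured compounds share one core and differ only at the far end of a saturated chain carried by the ring amine. Compound 1 `CC1CC(=O)N(c2ccccc2C(=O)OCC2CCCN(CCCCCc3ccccc3)C2)C1=O` and compound 2 `CC1CC(=O)N(c2ccccc2C(=O)OCC2CCCN(CCCCCCc3ccccc3)C2)C1=O` are both weak. In an in vitro functional assay on HEK ts201 cells for antagonist activity at Neuronal acetylcholine receptor; alpha4/beta2 (Homo sapiens), read by fluorescence and calcium flux (on this read-out lower numbers stand for stronger inhibition and higher numbers for weaker inhibition), compound 1 gives 24500 nM and compound 2 gives 29500 nM. Among the measured compounds shown here, the one step between them, a 1.2-fold higher number from compound 1 to compound 2 (0.08 log units; within the scatter), is flat. Compound 2 thus carries the highest of the two numbers, though its nearest neighbour, compound 1, sits within the scatter of it.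

Compound 3 `COc1ccc(OCCCCCN2CCCC(COC(=O)c3ccccc3N3C(=O)CC(C)C3=O)C2)cc1` keeps the whole of compound 2 except the chain end, where the change is 4-methoxyphenoxy in place of benzyl on a saturated chain carbon, five bonds along the chain from an amine nitrogen in a ring. For the measured compounds named here, no measured step tests this exchange directly; the only step on record, from compound 1 to compound 2, changed the chain length and moved nothing. On that basis no movement beyond the scatter is expected in this assay for compound 3. The step that this estimate implies, a 1.2-fold lower number from compound 2 to compound 3 (0.07 log units; within the scatter), is expected to be small and of uncertain direction. Compound 3 is therefore estimated at 25000 nM, with a range from 10000 nM to 70000 nM.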

Compound 3, half-maximal inhibitory concentration: 14500 nM
The estimate for compound 3 lay 1.7-fold (0.24 log units) above the measured number; measured number inside the range.
By their numbers in this assay, from the lowest: compounds 3, 1 and 2 (each within the scatter of the next, the first and the last beyond it).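

In this assay, among the compounds shown here, the exchange of 4-methoxyphenoxy for benzyl on a saturated chain carbon, five bonds along the chain from an amine nitrogen in a ring, gives the first step at this position to pass beyond the scatter, a 2.0-fold lower number from compound 2 to compound 3 (0.31 log units; beyond the scatter). The step is modest, and the comparison with the phenyl-ended compound reads differently: 4-methoxyphenoxy in place of phenyl at the same place gives a 1.7-fold lower number from compound 1 to compound 3 (0.23 log units; within the scatter), which stays within the scatter, so compound 3 is not clearly set apart from compound 1. The chain end can therefore shift this number slightly, but the shift is close to the limit of what the assay can resolve, and no supporting measurement offers an explanation for it.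

The compounds shown do not separate the contribution of the phenoxy oxygen from that of the methoxy group, since a plain phenoxy end and a 4-methoxyphenyl end are absent from this set. On these data alone, it also remains open whether a more different chain end, such as a carboxylic acid or an amine, would move the number further than 4-methoxyphenoxy does.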